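Swapping the aminophenyl arm for a bromohydroxyphenyl

A few compounds are considered here, and "the series" means these few. Any claim that something is new, unique, unknown or untested is made for them only; others in the source may bear on it.

Compound 1, `C/C(=N\NC(=O)c1cccc(S(=O)(=O)N2CCOCC2)c1)c1cccc(N)c1`, is the starting point here. In a functional assay on PC-3 cells (Homo sapiens) for antiproliferative activity, read by MTT assay, with a stated time of 72 h (a lower number here means a stronger inhibitor, a higher number a weaker inhibitor), compound 1 gives only a limit, > 100000 nM, not a number. Two close relatives have been measured the same way. Compound 2, `C/C(=N\NC(=O)c1cccc(S(=O)(=O)N2CCOCC2)c1)c1cccc(O)c1`, carries hydroxy in place of amino on an aromatic carbon. In this assay compound 2 also gives only a limit, > 100000 nM. Compound 3, `C/C(=N\NC(=O)c1cccc(S(=O)(=O)N2CCOCC2)c1)c1cc(O)ccc1O`, carries 2,5-dihydroxyphenyl in place of 3-aminophenyl on a carbon with a double bond to nitrogen. In this assay compound 3 again gives only a limit, > 100000 nM. The steps among them, a step that the two limits leave unreadable from compound 1 to compound 2, a step that the two limits leave unreadable from compound 1 to compound 3 and a step that the two limits leave unreadable from compound 2 to compound 3, therefore cannot be sized, and the whole picture so far is summed up in the limit of > 100000 nM in this assay, at which 3 of the 3 values shown sit.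

The compound still to be measured is compound 4, `C/C(=N\NC(=O)c1cccc(S(=O)(=O)N2CCOCC2)c1)c1cc(Br)ccc1O`. Compared with compound 1 the change is 5-bromo-2-hydroxyphenyl in place of 3-aminophenyl on a carbon with a double bond to nitrogen. The nearest comparisons are the step from compound 1 to compound 3 and the step from compound 2 to compound 3, and both stay unreadable because every value sits at the limit (the limit of > 100000 nM in this assay, at which 3 of the 3 values shown sit). So neither a direction nor a size can be read for the coming step; the expectation is only that compound 4 will behave like its relatives. Compound 4 is therefore expected near 100000 nM, within 30000 nM to 300000 nM, and most likely reported again only as a limit. The step this estimate implies is a number no higher from compound 1 to compound 4 (the limit leaves the size open).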

Compound 4, half-maximal inhibitory concentration: 6890 nM
Estimate against measurement, compound 4: 15-fold (1.16 log units) above; measured number outside the range, below it.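

For the compounds shown here, the arm on the carbon with a double bond to nitrogen can bring this series within reach of a real number: in this assay, compound 4 gives 6890 nM, the first value that is not a limit. The closest comparison is also the most telling, as bromo in place of hydroxy on an aromatic carbon gives an at least 14-fold lower number from compound 3 to compound 4 (1.16 log units; beyond the scatter), so a single group on an otherwise unchanged arm is enough to produce a large step. The wider swaps of the whole arm agree, with an at least 14-fold lower number from compound 1 to compound 4 (1.16 log units; beyond the scatter) and an at least 14-fold lower number from compound 2 to compound 4 (1.16 log units; beyond the scatter), while the steps among compound 1, compound 2 and compound 3 still cannot be read, and these earlier values offered no such contrast: the limit of > 100000 nM in this assay, at which 3 of the 4 values shown sit.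

The compounds shown leave open whether bromo needs the hydroxy of the 5-bromo-2-hydroxyphenyl arm to reach this value, and whether chloro, iodo or a methyl group could take the place of bromo with a similar result. On these data alone, the full size of each new step also stays open, as all three are counted from a limit and not from a number.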